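A few compounds are considered here, and "the series" means these few. Any claim that something is new, unique, unknown or untested is made for them only; others in the source may bear on it.

Within the data shown here, compound 2 `O=C1N(Cc2cccc(Cl)c2)CCC12CCN(C(c1ccc(F)cc1)c1ccc(F)cc1)CC2` gives 91% in a functional assay on cells for antagonist activity at Voltage-dependent T-type calcium channel subunit alpha-1H (Homo sapiens), read by patch clamp, tested at 0.3 uM (a lower number here means less inhibition, a higher number more inhibition at the concentration tested (going by the name of the read-out)), the higher of the two numbers measured so far. Compound 1 `CC(C)C(C(C)C)N1CCC2(CCN(Cc3ccc(Cl)cc3)C2=O)CC1`, which differs from it at several positions, gives 40% in this assay. Compound 3 `CC(C)(C)CCN1CCC2(CCN(C(c3ccc(F)cc3)c3ccc(F)cc3)CC2)C1=O` has not been measured; it differs from compound 2 by neopentyl in place of 3-chlorophenyl on a saturated chain carbon bound to an amide-type nitrogen in a ring. Among the measured compounds shown here, no measured pair shows this kind of change, so the expectation rests on the two numbers alone: the step of a number 23 percentage points lower from compound 2 to compound 3 (beyond the scatter) is expected to lower inhibition by more than the usual scatter. Compound 3 is estimated at 68%, within a range of 45% to 88%.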

Compound 3, a percentage reported as inhibition, at one concentration (the size of the read-out at that concentration, not a potency): 44%
Estimate against measurement, compound 3: 24 percentage points above, and the stated range ends above it.
By their numbers in this assay, from the lowest: compounds 1 and 3 (each within the scatter of the next); then compound 2.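

Neopentyl in place of 3-chlorophenyl on a saturated chain carbon bound to an amide-type nitrogen in a ring gives a number 47 percentage points lower from compound 2 to compound 3 (beyond the scatter) in this assay. With the rest of the structure held fixed, this position therefore clearly affects inhibition at the concentration tested, which the earlier pair, differing at several positions, could not isolate. Nothing at hand explains the size of this step.

Open, from the compounds shown here alone, is whether the aromatic ring or its chlorine matters more. An unsubstituted benzyl or a cyclohexylmethyl group at this position would separate the two.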